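Removing the propyl group from the ring nitrogen of compound 1

This account rests on a few compounds, and the source may have more. Where it says the series, first, only, none or still open, it means among the compounds named here.

Measured so far in a functional assay on NCI-H460 cells (Homo sapiens) for cytotoxicity, read by MTT assay, with a stated time of 72 h; on this read-out higher numbers stand for weaker inhibition and lower numbers for stronger inhibition:
- compound 1 `CCCN1C/C(=C\c2ccc(OC)c(OC)c2)C(=O)/C(=C/c2ccc(OC)c(OC)c2)C1` gives 4100 nM
- compound 2 `CCC(=O)N1C/C(=C\c2cc(OC)c(OC)c(OC)c2)C(=O)/C(=C/c2cc(OC)c(OC)c(OC)c2)C1` gives 2700 nM
- compound 3 `COc1cc(/C=C2\CN(C(=O)c3ccccc3F)C/C(=C\c3cc(OC)c(OC)c(OC)c3)C2=O)cc(OC)c1OC` gives 1500 nM

Among these three numbers compound 1 stands highest; compound 2 lies within the scatter of it, while compound 3 sits beyond the scatter on the lower side. Compound 4 `COc1ccc(/C=C2\CNC/C(=C\c3ccc(OC)c(OC)c3)C2=O)cc1OC` keeps the shared core of compound 1 and differs in one place: hydrogen in place of propyl on an amine nitrogen in a ring.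

Only one measured step connects two of these compounds, a 1.8-fold lower number from compound 2 to compound 3 (0.26 log units; within the scatter), and it concerns a group on a carbonyl carbon, not the amine nitrogen in the ring. It therefore says little about what removing the propyl group does. Among the compounds with values here, no measured pair shows the effect of a hydrogen on that ring nitrogen, so there is no basis for expecting a shift in either direction beyond the scatter.

On that footing, compound 4 is expected to give about 4000 nM in this assay, with a range from 1300 nM to 12000 nM. The estimated step of a 1.0-fold lower number from compound 1 to compound 4 (0.01 log units; within the scatter) is therefore taken as essentially flat, with wide uncertainty reflecting the absence of a comparable measured step.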

Compound 4, half-maximal inhibitory concentration: 6400 nM
Beside the measured number, compound 4's estimate is 1.6-fold (0.20 log units) below it; the range from low to high includes it.
By their numbers in this assay, from the lowest: compounds 3, 2, 1 and 4 (each within the scatter of the next, the first and the last beyond it).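

In this assay, swapping the propyl group on the ring nitrogen for hydrogen gives a 1.6-fold higher number from compound 1 to compound 4 (0.19 log units; within the scatter), so this change produces no shift that can be told apart from the ordinary spread of repeated measurements. Within the data shown here, this is the first direct reading at this position, as the earlier step concerned a group on a carbonyl carbon, and it shows that, for this pair, a ring nitrogen carrying only hydrogen performs much like one carrying propyl. No measurement shown here offers an explanation for this result.

On these data alone, it remains open whether a methyl group, a longer chain such as butyl, or a benzyl group on the same nitrogen of the core of compound 1 would move the number beyond the scatter, since one pair samples only hydrogen and propyl. Compound 2 and compound 3 do carry carbonyl groups on their ring nitrogen, but they differ from compound 1 in more than one place, so they cannot show what a carbonyl group at this nitrogen does on its own.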